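Swapping the amide side chain on a weak melanocortin binder

The source may report more compounds than this note shows. Statements on the series, on what has been measured and on what is new or still open speak of the compounds shown alone.

Three compounds share a core in which a piperazine-type amide is joined to an aryl ring bearing a branched amine. In an assay on HEK293 cells for displacement of a labelled ligand from Melanocortin receptor 4 (Homo sapiens) (a lower number here means a stronger inhibitor, a higher number a weaker inhibitor), compound 1 `CC(C)C[C@H](N)c1cc(Cl)ccc1N1CCN(C(=O)C(C)Cc2ccc(Cl)cc2)CC1` gives 67 nM and compound 3 `Cc1ccc(N2CCN(C(=O)[C@H](C)Cc3ccc(Cl)cc3F)CC2)c([C@@H](N)CC(C)C)c1` gives 20 nM. Compound 2 `Cc1ccc(OCC(=O)N2CCN(c3ccc(C(F)(F)F)cc3[C@@H](N)CC(C)C)CC2)cc1` gives 4400 nM in this assay, the highest of the three numbers, standing beyond the scatter from both compound 1 and compound 3.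

Compound 4 `COc1ccc(CC(C)C(=O)N2CCN(c3ccc(C(F)(F)F)cc3[C@@H](N)CC(C)C)CC2)cc1` is built from compound 2 by one change on the carbonyl carbon: 1-(4-methoxybenzyl)ethyl in place of (4-methylphenoxy)methyl on a carbonyl carbon. The chain that enters resembles the chains carried on the carbonyl carbon by compound 1 and compound 3, whereas the chain that leaves is found only in compound 2, the weakest of the set. Going by the values given here, no single-change step between measured compounds is available, so the size of the effect rests on this resemblance alone.

Compound 4 is therefore expected to bind more tightly than compound 2, with a step of a 29-fold lower number from compound 2 to compound 4 (1.47 log units; beyond the scatter) in this assay that goes well beyond the scatter. The estimate for compound 4 in this assay is 150 nM, within a range from 30 nM to 900 nM, the wide span reflecting that its core differs from those of compound 1 and compound 3.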

Compound 4, inhibition constant: 120 nM
Estimate against measurement, compound 4: 1.3-fold (0.10 log units) above, within the range that was stated.
By their numbers in this assay, from the lowest: compound 3; then compounds 1 and 4 (each within the scatter of the next); then compound 2.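

In this assay the group on the carbonyl carbon proves to matter a great deal: with the rest of the molecule unchanged, 1-(4-methoxybenzyl)ethyl in place of (4-methylphenoxy)methyl gives a 37-fold lower number from compound 2 to compound 4 (1.56 log units; beyond the scatter) and so makes a large difference. Going by these compounds alone, no two of the earlier compounds differed in one place only, so this is the first direct measure of what this position can do on its own, and it shows that the high number of compound 2 is not fixed by the rest of its structure. Nothing at hand explains why the entering chain gives the lower number.

The swap alters several things at once, as the two chains differ in how the ring is attached to the carbonyl carbon and in the group the ring carries, so the compounds shown leave open which of these parts accounts for the step. Also open, on these data alone, is how this position would respond to a longer chain or to a chain ending in a carboxylic acid.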